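Dropping a Methoxy Group from the Dimethoxyphenyl Ketone

A few compounds are considered here, and "the series" means these few. Any claim that something is new, unique, unknown or untested is made for them only; others in the source may bear on it.

Measured so far in a functional assay on SW-620 cells (Homo sapiens) for inhibition, read by sulforhodamine B assay, with a stated time of 48 h; on this read-out lower numbers stand for stronger inhibition of growth and higher numbers for weaker inhibition of growth:
compound 1 `COc1cc(-c2cc(/C=C/C(=O)c3ccc(N)cc3)[nH]n2)cc(OC)c1OC` gives 6370 nM
compound 2 `COc1cc(-c2cc(/C=C/C(=O)c3ccc(Cl)c(Cl)c3)[nH]n2)cc(OC)c1OC` gives 79600 nM
compound 3 `COc1ccc(C(=O)/C=C/c2cc(-c3cc(OC)c(OC)c(OC)c3)n[nH]2)cc1OC` gives 2990 nM

Compound 3 shows the lowest number of the three. Its nearest neighbour is compound 1, with a 2.1-fold lower number from compound 1 to compound 3 (0.33 log units; beyond the scatter) separating them, and compound 2 lies furthest away, with a 27-fold lower number from compound 2 to compound 3 (1.43 log units; beyond the scatter) between them. All three share the same core and differ only in the aromatic ring attached to the carbonyl carbon.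

Compound 4 `COc1ccc(C(=O)/C=C/c2cc(-c3cc(OC)c(OC)c(OC)c3)n[nH]2)cc1` is not yet measured. It differs from compound 3 by hydrogen in place of methoxy on an aromatic carbon; the change sits on an aromatic carbon of a six-membered aromatic ring of carbon only, ortho to a methoxy group and meta to a large group, so the 3,4-dimethoxyphenyl becomes a 4-methoxyphenyl.

Among the compounds with values here, no measured step removes a single group from this ring; the steps seen swap the whole ring substitution pattern, and those were large, as in a 12-fold higher number from compound 1 to compound 2 (1.10 log units; beyond the scatter) and a 27-fold lower number from compound 2 to compound 3 (1.43 log units; beyond the scatter), or modest, as in a 2.1-fold lower number from compound 1 to compound 3 (0.33 log units; beyond the scatter). Taking away a methoxy is a smaller change than any of these, so for compound 4 a step of a 1.5-fold higher number from compound 3 to compound 4 (0.18 log units; within the scatter) in this assay is expected, towards a somewhat higher number. The estimate for compound 4 is 4500 nM, with a range from 1500 nM to 13500 nM.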

Compound 4, concentration for total growth inhibition: 3470 nM
Estimate against measurement, compound 4: 1.3-fold (0.11 log units) above, and the stated range covers the measured number.
By their numbers in this assay, from the lowest: compounds 3, 4 and 1 (each within the scatter of the next, the first and the last beyond it); then compound 2.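

In this assay, within the data shown here, this is the first step that takes a single methoxy off the ring on the carbonyl carbon, and with hydrogen in its place it gives a 1.2-fold higher number from compound 3 to compound 4 (0.06 log units; within the scatter) within the scatter, so the 3,4-dimethoxyphenyl and the 4-methoxyphenyl cannot be told apart by this read-out. The 4-methoxyphenyl also lies within the scatter of the 4-aminophenyl, as a 1.8-fold lower number from compound 1 to compound 4 (0.26 log units; within the scatter) shows, even though the 3,4-dimethoxyphenyl stands just beyond the scatter from that same ring, which means small gaps among these three compounds should not be over-read. The 3,4-dichlorophenyl remains the clear outlier, with a 23-fold lower number from compound 2 to compound 4 (1.36 log units; beyond the scatter) adding a large step to the two already seen, and no supporting data bear on why any of these steps has the size it has.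

From the compounds shown here alone, with only these four compounds, it remains open whether the methoxy that stays on the ring matters, since no plain phenyl ring is among them to test that. Going by these compounds, it is also open whether another group in place of the removed methoxy, such as a hydroxyl, a fluorine or a longer ethoxy, would stay within the scatter as hydrogen does.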